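A few compounds are considered here, and "the series" means these few. Any claim that something is new, unique, unknown or untested is made for them only; others in the source may bear on it.

Measured compounds in a functional assay on MCF7 cells (Homo sapiens) for cytotoxicity, read by sulforhodamine B assay; a higher number here means a weaker inhibitor, a lower number a stronger inhibitor:
- compound 1 `C=C1[C@@H](OC(C)=O)C[C@@H]2[C@](C)(CO[Si](C)(C)C(C)(C)C)[C@H](OC(C)=O)CC[C@@]2(C)[C@@H]1C[C@@H](Nc1ccccc1F)C1=CCOC1=O`: 2930 nM
- compound 2 `C=C1[C@@H](OC(C)=O)C[C@@H]2[C@](C)(COC=O)[C@H](OC(C)=O)CC[C@@]2(C)[C@@H]1C[C@@H](Nc1ccccc1C(=O)O)C1=CCOC1=O`: 30800 nM
- compound 3 `C=C1[C@@H](OC(C)=O)C[C@@H]2[C@](C)(CO[Si](C)(C)C(C)(C)C)[C@H](OC(C)=O)CC[C@@]2(C)[C@@H]1C/C=C1/C(=O)OC[C@H]1OC(C)=O`: 4540 nM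

Compound 1 gives the lowest of the three numbers in this assay. Compound 3 sits nearest to it, and the gap between compound 1 and compound 3 lies within the usual scatter, so no order between them can be claimed. Compound 2 stands furthest away, and its gap from compound 1 lies beyond the scatter; compound 2, however, differs from compound 1 in more than one place, so no single step can be read from that pair.

Compound 4 `C=C1[C@@H](OC(C)=O)C[C@@H]2[C@](C)(CO[Si](C)(C)C(C)(C)C)[C@H](OC(C)=O)CC[C@@]2(C)[C@@H]1C[C@@H](Nc1ccc(O)cc1)C1=CCOC1=O` is not yet measured. Relative to compound 1 the change is 4-hydroxyphenyl in place of 2-fluorophenyl on an amine nitrogen. Among the compounds with values here, no measured pair shows this change on its own. Within the data shown here, with no such step available, the size of the change is expected to be modest, leaning toward a weaker inhibitor, and it may well stay within the scatter. Compound 4 is therefore estimated at 5000 nM in this assay, with a range from 1500 nM to 20000 nM, which would mean an expected step of a 1.7-fold higher number from compound 1 to compound 4 (0.23 log units; within the scatter).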

Compound 4, half-maximal inhibitory concentration: 5220 nM
Compound 4: the middle estimate sits 1.0-fold (0.02 log units) below what was measured; measured number inside the range.
By their numbers in this assay, from the lowest: compounds 1, 3 and 4 (each within the scatter of the next); then compound 2.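

In this assay, within the data shown here, 4-hydroxyphenyl in place of 2-fluorophenyl on the amine nitrogen gives a 1.8-fold higher number from compound 1 to compound 4 (0.25 log units; within the scatter), the first step that can be read at a single place. The position therefore accepts a ring bearing a hydrogen-bond donor and acceptor, which 2-fluorophenyl lacks, with no change that can be claimed in this assay. No measurement at hand offers an explanation for this result.

The step replaces the fluorine with a hydroxyl and changes the substituent's place on the ring at once, so the compounds shown cannot separate these two differences. They also leave open how an unsubstituted phenyl, a pyridine ring or a saturated cyclohexyl group on the same nitrogen would read in this assay.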